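Hydroxyphenyl-pyridine series: repositioning a hydroxyl on the pendant phenyl

The source may hold more compounds than are shown below. What is called first, only, known or untested is meant among the compounds shown, and "the series" means these compounds.

Measured compounds:
compound 1 `Oc1cccc(-c2cc(-c3cccs3)cc(-c3cccc(O)c3)n2)c1`: 0%
compound 2 `Oc1cccc(-c2cc(-c3ccsc3)cc(-c3ccccc3O)n2)c1`: "not determined" (no result reported)

Compound 1 `Oc1cccc(-c2cc(-c3cccs3)cc(-c3cccc(O)c3)n2)c1` carries two 3-hydroxyphenyl groups and a thiophen-2-yl group on the shared core. In an assay on isolated protein for inhibition of DNA topoisomerase 1 (Homo sapiens), with a stated time of 30 min, tested at 20 uM (on this read-out lower numbers stand for a weaker effect and higher numbers for a stronger effect at the one concentration tested), compound 1 gives 0%, so no inhibition was seen for it at the single concentration used. Compound 2 `Oc1cccc(-c2cc(-c3ccsc3)cc(-c3ccccc3O)n2)c1` carries one 3-hydroxyphenyl group, one 2-hydroxyphenyl group and a thiophen-3-yl group. For compound 2 this assay returned "not determined" (no result reported), so compound 2 stands nowhere on the numbers; there is no value to place it against compound 1.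

Compound 3 `Oc1cccc(-c2cc(-c3ccsc3)cc(-c3cccc(O)c3)n2)c1` is the next compound. Its difference from compound 2 is 3-hydroxyphenyl in place of 2-hydroxyphenyl on an aromatic carbon. With no result for compound 2, no step size can be drawn for this change. Among the measured compounds shown here, the only anchor is compound 1, which shares both 3-hydroxyphenyl groups with compound 3 and shows no effect. On that basis the expectation for compound 3 in this assay is a value close to that of compound 1, and compound 3 is estimated at 3%, within 0% to 15%.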

Compound 3, a percentage reported as inhibition, at one concentration (the size of the read-out at that concentration, not a potency): 4.5%
Compound 3: the middle estimate sits 1.5 percentage points below what was measured; the range from low to high includes it.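

Thiophen-3-yl in place of thiophen-2-yl, with both 3-hydroxyphenyl groups kept, gives in this assay a number 4.5 percentage points higher from compound 1 to compound 3 (within the scatter) and so the two thiophene attachments do not separate these compounds at the one concentration tested. The step from 2-hydroxyphenyl to 3-hydroxyphenyl cannot be read: compound 2 carries no number, and the hydroxyl shift on the pendant phenyl therefore has no size in this series. Nothing at hand offers an explanation for the result beyond the values themselves.

Open, on these data alone, is whether 2-hydroxyphenyl gives any read-out in this assay at all, and whether any compound reaches a read-out beyond the scatter of compound 1 and compound 3. Also open, as far as these compounds go, is what an amine or a carboxylic acid in place of a hydroxyl on the pendant phenyl would give, or a longer chain in place of the thiophene, since the two thiophene isomers alone span only the narrow range printed here.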